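The source may hold more compounds than are shown below. What is called first, only, known or untested is meant among the compounds shown, and "the series" means these compounds.

Three compounds with a shared core carry different aryl groups on the carbonyl carbon. Compound 1 `COc1ccc(-c2cc(/C=C/C(=O)c3ccc(N)cc3)[nH]n2)cc1` gives in a functional assay on SK-OV-3 cells (Homo sapiens) for cytotoxicity, read by sulforhodamine B assay, with a stated time of 48 h, tested at 0.01 uM (on this read-out lower numbers stand for a stronger effect and higher numbers for a weaker effect at the one concentration tested), a value of 101%. Compound 2 `COc1cc(-c2cc(/C=C/C(=O)c3ccc(Cl)c(Cl)c3)[nH]n2)cc(OC)c1OC` gives 99% in this assay, and compound 3 `COc1ccc(C(=O)/C=C/c2cc(-c3cc(OC)c(OC)c(OC)c3)n[nH]2)cc1OC` gives 100%. Compound 2 sits at the lower edge of this narrow cluster, but compound 3 lies within the scatter of it, as does compound 1, so the three numbers cannot be told apart.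

Compound 4 `COc1cc(-c2cc(/C=C/C(=O)c3ccc(F)c(F)c3)[nH]n2)cc(OC)c1OC` is not yet measured. It differs from compound 2 in one place: 3,4-difluorophenyl in place of 3,4-dichlorophenyl on a carbonyl carbon. Within the data shown here, the one step that bears on this change is the exchange of the aryl group on the same carbonyl carbon, a number 1 percentage points higher from compound 2 to compound 3 (within the scatter), which was within the scatter. With all three measured numbers close to no effect at this concentration, no step beyond the scatter is expected for compound 4. Compound 4 is therefore estimated at 100%, with a range from 91% to 108%, which means an expected step of a number 1 percentage points higher from compound 2 to compound 4 (within the scatter).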

Compound 4, a percentage reported as activity, at one concentration (the size of the read-out at that concentration, not a potency): 98%
The estimate for compound 4 lay 2 percentage points above the measured number, and the stated range covers the measured number.
By their numbers in this assay, from the lowest: compounds 4, 2, 3 and 1 (each within the scatter of the next).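

In this assay, 3,4-difluorophenyl in place of 3,4-dichlorophenyl on the carbonyl carbon gives a number 1 percentage points lower from compound 2 to compound 4 (within the scatter), and 3,4-difluorophenyl in place of 3,4-dimethoxyphenyl gives a number 2 percentage points lower from compound 3 to compound 4 (within the scatter). Among these compounds, the earlier compounds offered only one step at this place, and these two add a fluorine-bearing aryl group, so three aryl groups on this carbonyl carbon now cannot be told apart at the one concentration tested. No supporting data are available to explain this lack of separation.

The compounds shown leave open whether these aryl groups would separate at a higher concentration, as all the numbers lie close to no effect. They also leave open whether a carboxylic acid or a nitrile on this aryl ring would produce a step beyond the scatter.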